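Amide substituent variation at the pyridine carboxamide

The source may report more compounds than this note shows. Statements on the series, on what has been measured and on what is new or still open speak of the compounds shown alone.

Measured so far:
compound 1 `C[C@H](NC(=O)c1ccc(C#Cc2cccc(F)c2)cn1)C(C)(C)C` — 20%
compound 2 `O=C(NCC1CCC1)c1ccc(C#Cc2cccc(F)c2)cn1` — 4.7%

In an ADME assay on HEK293 cells for agonist activity at metabotropic glutamate receptor 5 (Rattus norvegicus), read by fluorescence and calcium flux (on this read-out lower numbers stand for smaller maximal responses and higher numbers for larger maximal responses), compound 2 stands lowest of the two numbers shown, with compound 1 the nearest. Within the data shown here, the only measured step is a number 15.3 percentage points lower from compound 1 to compound 2 (beyond the scatter). Compound 3 `CC(C)(CO)NC(=O)c1ccc(C#Cc2cccc(F)c2)cn1` differs from compound 2 by 1-(hydroxymethyl)-1-methylethyl in place of cyclobutylmethyl on an amide-type nitrogen. Among the measured compounds shown here, no measured step covers a hydroxyl-bearing group here, so that step informs only loosely; it shows that the amide substituent can move the maximal response by a modest amount. For compound 3 a small rise toward the middle of the two measured numbers is expected, a number 7.3 percentage points higher from compound 2 to compound 3 (within the scatter), giving an estimate of 12% with a range from 0% to 30%.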

Compound 3, largest response reached (reported as efficacy), in percent of the reference or control that the assay uses: 9.3%
Compound 3: the middle estimate sits 2.7 percentage points above what was measured; the range from low to high includes it.
By their numbers in this assay, from the lowest: compounds 2 and 3 (each within the scatter of the next); then compound 1.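

In this assay, a hydroxyl-bearing open chain on the amide-type nitrogen and the cyclobutylmethyl group are not told apart, the step being a number 4.6 percentage points higher from compound 2 to compound 3 (within the scatter) and so leaving the ring swap without a readable effect. Set against 1,2,2-trimethylpropyl, the same 1-(hydroxymethyl)-1-methylethyl group gives a number 10.7 percentage points lower from compound 1 to compound 3 (beyond the scatter), which leaves compound 1 alone apart from the other two. No evidence on hand explains either step.

Open, going by these compounds, is whether 1,2,2-trimethylpropyl owes its place to its branching or to its carbon count. On these data alone, how an amine, a carboxylic acid or a longer chain at this nitrogen would read remains unknown.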